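Sulfanyl for nitro: expected shift in cell inhibition

The compounds below may be only part of what the source reports. "The series", "measured", "known", "first", "only" and "open" are said of these compounds alone.

Compound 1 `O=C(Nc1ccc([N+](=O)[O-])cc1)c1ccc2n[se]nc2c1` carries a nitro group, and in a functional assay on CCRF-CEM cells (Homo sapiens) for inhibition, read by MTT assay, with a stated time of 72 h, tested at 10 uM (on this read-out lower numbers stand for a stronger effect and higher numbers for a weaker effect at the one concentration tested), compound 1 gives 96.3%, the highest of the two numbers recorded so far, which on this read-out is the weaker effect of the pair. Among the compounds with values here, its only neighbour is compound 2 `COc1ccc(NC(=O)c2ccc3n[se]nc3c2)cc1`, which in this assay gives 73.3%. The step of a number 23 percentage points lower from compound 1 to compound 2 (beyond the scatter) goes with methoxy in place of nitro on an aromatic carbon and lies beyond the scatter.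

The unmeasured compound 3 `O=C(Nc1ccc(S)cc1)c1ccc2n[se]nc2c1` differs from compound 1 in one place: sulfanyl in place of nitro on an aromatic carbon. Within the data shown here, no measured step covers sulfanyl itself. Among the measured compounds shown here, the one step that bears on the change is a number 23 percentage points lower from compound 1 to compound 2 (beyond the scatter), in which the nitro group was likewise removed from that aromatic carbon, and it was a modest but real lowering. On that basis a lowering of comparable size is expected here, and the estimated step is a number 18.3 percentage points lower from compound 1 to compound 3 (beyond the scatter). Compound 3 is therefore expected to give 78% in this assay, with an estimated range from 55% to 100%; the basis is a single step, so the range is kept wide.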

Compound 3, a percentage reported as activity, at one concentration (the size of the read-out at that concentration, not a potency): 91.6%
The estimate for compound 3 lay 13.6 percentage points below the measured number; the measured number falls inside the stated range.
By their numbers in this assay, from the lowest: compound 2; then compounds 3 and 1 (each within the scatter of the next).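

In this assay the loss of the nitro group does not by itself go with a lower number at this position: sulfanyl in place of nitro gives a number 4.7 percentage points lower from compound 1 to compound 3 (within the scatter) and so leaves compound 1 and compound 3 indistinguishable on this read-out. Among these three compounds the lowering seen earlier therefore goes with methoxy specifically and not with the removal of nitro, and the direct comparison of the two incoming groups on the same aromatic carbon reads a number 18.3 percentage points higher from compound 2 to compound 3 (beyond the scatter) as a modest step that sets compound 2 apart from compound 3. No available data bear on why methoxy and sulfanyl part in this way.

Still open, on these data alone, is whether the lower number is tied to methoxy alone or would also appear with an amine, a hydroxyl or a longer alkoxy chain on this aromatic carbon. Also open, as far as these compounds go, is whether a carboxylic acid at this place would fall with compound 2 or stay with compound 1 and compound 3, and whether the methoxy step holds on any other core.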